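Ethyl ester in place of the acid on a second core

The source may hold more compounds than are shown below. What is called first, only, known or untested is meant among the compounds shown, and "the series" means these compounds.

Measured compounds:
compound 1 `CCCCCCC(Sc1nc(Cl)cc(Oc2ccc3ncccc3c2)n1)C(=O)O` with 91.4%
compound 2 `CCCCCCC(Sc1nc(Cl)cc(Oc2ccc3ncccc3c2)n1)C(=O)OCC` with 67.4%
compound 3 `O=C(O)C(Sc1nc(Cl)cc(Nc2ccc3ncccc3c2)n1)c1ccccc1` reported as "not active" (no number reported)

In an assay for inhibition of Polyunsaturated fatty acid 5-lipoxygenase (Homo sapiens), tested at 1 uM (on this read-out higher numbers stand for a weaker effect at the one concentration tested and lower numbers for a stronger effect), compound 1 gives 91.4% and compound 2 gives 67.4%. The change between them is ethyl in place of hydrogen on an oxygen next to a carbonyl group and it made a step of a number 24 percentage points lower from compound 1 to compound 2 (beyond the scatter). Compound 3 carries a different core; the difference between the two cores is not broken down here. In this assay compound 3 is reported as "not active" (no number reported), with no number given. Compound 4 `CCOC(=O)C(Sc1nc(Cl)cc(Nc2ccc3ncccc3c2)n1)c1ccccc1` is not yet measured. It differs from compound 3 by ethyl in place of hydrogen on an oxygen next to a carbonyl group, the same change as from compound 1 to compound 2, at the same place. For the measured compounds named here, compound 4 is expected to give a read-out somewhat lower than that of compound 3, and the size of that step is expected to resemble a number 24 percentage points lower from compound 1 to compound 2 (beyond the scatter), because the only measured example of this change is a number 24 percentage points lower from compound 1 to compound 2 (beyond the scatter). Since compound 3 has no number, the estimate for compound 4 is 85%, within 60% to 100%.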

Compound 4, a percentage reported as activity, at one concentration (the size of the read-out at that concentration, not a potency): 52.7%
For compound 4 the middle estimate is 32.3 percentage points above the measured one; measured number outside the range, below it.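

In this assay compound 3 has no number, and the step to compound 4 cannot be read. The compounds shown leave open how the ethoxycarbonyl and carboxy forms compare on this core. Nothing measured here explains the result.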